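The compounds below may be only part of what the source reports. "The series", "measured", "known", "first", "only" and "open" are said of these compounds alone.

Measured so far in an assay on HL-60 cells for agonist activity at vitamin D3 receptor (Homo sapiens), read by microscopy, with a stated time of 96 h; on this read-out higher numbers stand for an effect only at larger amounts of compound and lower numbers for an effect already at smaller amounts: compound 1 `CCn1c(C(=O)NCCN(C)C)ccc1C(CC)(CC)c1ccc(OCC(=O)C(C)(C)C)c(C)c1` gives 77 nM; compound 2 `C=CCN(C)C(=O)c1ccc(C(CC)(CC)c2ccc(OCC(=O)C(C)(C)C)c(C)c2)n1CC` gives 21600 nM; compound 3 `CC[C@@H](C)[C@H](NC(=O)c1ccc(C(CC)(CC)c2ccc(OCC(O)C(C)(C)C)c(C)c2)n1CC)C(=O)OC` gives 26 nM.

Compound 3 stands lowest of the three numbers; compound 1 lies nearest to it and compound 2 furthest. Compound 4 `C#CCNC(=O)c1ccc(C(CC)(CC)c2ccc(OCC(O)C(C)(C)C)c(C)c2)n1CC` differs from compound 3 by propargyl in place of 1-(methoxycarbonyl)-2-methylbutyl on an amide-type nitrogen. Within the data shown here, the one measured step at the amide end, a 280-fold higher number from compound 1 to compound 2 (2.45 log units; beyond the scatter), was large, so changes on this nitrogen can move the number strongly in this assay; no step directly between compound 1 and compound 3 is available, their values only show the amide substituent matters. Compound 4 keeps the amide hydrogen but loses the ester-bearing chain, so a moderate rise is expected, a 3.8-fold higher number from compound 3 to compound 4 (0.59 log units; beyond the scatter); compound 4 is estimated at 100 nM within 30 nM to 400 nM.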

Compound 4, half-maximal effective concentration: 240 nM
Estimate against measurement, compound 4: 2.4-fold (0.38 log units) below; the measured number falls inside the stated range.
By their numbers in this assay, from the lowest: compound 3; then compound 1; then compound 4; then compound 2.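

In this assay, a 9.2-fold higher number from compound 3 to compound 4 (0.97 log units; beyond the scatter) shows that this amide-type nitrogen also responds when the amide hydrogen stays in place, though far less sharply than the earlier step at the amide end suggested. The change removes the methoxycarbonyl, the branched chain and both defined stereocentres at once, and this single step cannot separate them. Nothing available here explains the rise. Going by these compounds, whether a carboxylic acid in place of the methoxycarbonyl would keep the number low remains open. So does whether a propyl chain would behave like propargyl.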